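The source may hold more compounds than are shown below. What is called first, only, known or untested is meant among the compounds shown, and "the series" means these compounds.

Of the compounds shown here, two built on one shared core have been measured in an assay on isolated protein for inhibition of histone deacetylase 8 (Homo sapiens), read by mobility shift assay; on this read-out higher numbers stand for weaker inhibition and lower numbers for stronger inhibition. Compound 1 `O=C(NO)c1ccc(CN(Cc2ccccc2)S(=O)(=O)c2cc(F)c(F)c(F)c2F)cc1` gives 155 nM. Compound 2 `O=C(NO)c1ccc(CN(Cc2ccc(F)cc2)S(=O)(=O)c2cc(F)c(F)c(F)c2F)cc1` differs from compound 1 only by a fluoro in place of hydrogen on an aromatic carbon; in this assay compound 2 gives 860 nM. Among the measured compounds shown here, that single change reads as a 5.5-fold higher number from compound 1 to compound 2 (0.74 log units; beyond the scatter), so compound 2 stands as the higher of the two numbers, with compound 1 its only neighbour.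

Compound 3 `O=C(NO)c1ccc(CN(Cc2cccc(F)c2)S(=O)(=O)c2cc(F)c(F)c(F)c2F)cc1` keeps every atom of compound 2 but joins them differently: 3-fluorophenyl in place of 4-fluorophenyl on a saturated chain carbon bound to a sulfonamide nitrogen. Cut one bond further out, the same difference reads 4-fluorobenzyl to 3-fluorobenzyl. For the measured compounds named here, no measured step moves a fluorine from one aromatic carbon to another. Going by the values given here, the only step that touches this ring is a 5.5-fold higher number from compound 1 to compound 2 (0.74 log units; beyond the scatter), which shows that placing one fluorine on it changed the number in this assay. Shifting that fluorine could undo part of that change or leave it untouched. The expected step is therefore a 1.7-fold lower number from compound 2 to compound 3 (0.24 log units; within the scatter), a small move back toward compound 1 that may still fall within the scatter. Compound 3 is estimated at 500 nM, with a range from 150 nM to 1600 nM.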

Compound 3, half-maximal inhibitory concentration: 412 nM
Beside the measured number, compound 3's estimate is 1.2-fold (0.08 log units) above it; the measured number falls inside the stated range.
By their numbers in this assay, from the lowest: compound 1; then compound 3; then compound 2.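

In this assay, where the single fluorine sits on this ring matters: 3-fluorophenyl in place of 4-fluorophenyl, on a saturated chain carbon bound to a sulfonamide nitrogen, gives a step (a 2.1-fold lower number from compound 2 to compound 3 (0.32 log units; beyond the scatter)) that lies just beyond the usual scatter, even though the two compounds hold exactly the same atoms. Placing fluoro on the ring in this second way still gives a higher number than hydrogen (a 2.7-fold higher number from compound 1 to compound 3 (0.42 log units; beyond the scatter)), so among these three compounds, compound 1, with no fluorine on this ring, keeps the lowest number, and neither fluorinated compound matches it. These numbers show the size of each change, but nothing available explains why the two placements differ, or why either one weakens inhibition relative to compound 1.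

The compounds shown leave open whether this trend belongs to fluoro alone or would also hold for a chloro, methoxy or amine group on the same ring. They also leave open whether a carboxylic acid or a longer chain in place of the fluorobenzyl group would bring the number back to that of compound 1 or take it lower.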